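This account rests on a few compounds, and the source may have more. Where it says the series, first, only, none or still open, it means among the compounds named here.

Compound 2 `CCCC/N=C(\NC#N)Nc1cccnc1` was tested in a functional assay on the whole organism (blood, strain Wistar-Okamoto) with Rattus norvegicus as the target, with a stated time of 5 days (a lower number here means that less compound is needed, a higher number that more compound is needed for the effect), where compound 2 gives 20 mg/kg. Compound 1 `CCC/N=C(\NC#N)Nc1cccnc1` gives 20 mg/kg, and compound 3 `N#CN/C(=N\C1CCCCC1)Nc1cccnc1` gives 20 mg/kg, so compound 2 stands level with both at the digits reported, nearest to compound 1 and furthest from compound 3, though neither gap exceeds the scatter. The measured steps were no change at the digits printed from compound 1 to compound 2 (within the scatter), no change at the digits printed from compound 1 to compound 3 (within the scatter) and no change at the digits printed from compound 2 to compound 3 (within the scatter). Compound 4 `CC(C)C(C)(C)/N=C(\NC#N)Nc1cccnc1` differs from compound 2 by 1,1,2-trimethylpropyl in place of butyl on a double-bonded nitrogen. Within the data shown here, the steps that bear on this exchange at the double-bonded nitrogen are those from compound 2 to compound 3 and from compound 1 to compound 3, and neither moved the read-out beyond the scatter. The step expected in this assay is therefore no change at the digits printed from compound 2 to compound 4 (within the scatter), nothing beyond the scatter. The estimate for compound 4 is 20 mg/kg, within a range from 10 mg/kg to 40 mg/kg.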

Compound 4, minimum effective dose: 1 mg/kg
For compound 4 the middle estimate is 20-fold (1.30 log units) above the measured one, outside the stated range (below it).
By their numbers in this assay, from the lowest: compound 4; then compounds 1, 2 and 3 (each within the scatter of the next).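

At the double-bonded nitrogen in this assay, propyl, butyl and cyclohexyl had left the read-out level, yet 1,1,2-trimethylpropyl gives a 20-fold lower number from compound 2 to compound 4 (1.30 log units; beyond the scatter), along with a 20-fold lower number from compound 3 to compound 4 (1.30 log units; beyond the scatter) and a 20-fold lower number from compound 1 to compound 4 (1.30 log units; beyond the scatter). Among these compounds, the level values of the earlier compounds therefore did not mean that this position was indifferent to the group placed on it. No evidence is available that accounts for this large step. The compounds shown leave open whether a smaller branched group such as isopropyl, or a chain ending in an amine, would give a similar step.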